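Benzothiazole for Benzoxazole on an Inactive Sulfone

The compounds below may be only part of what the source reports. "The series", "measured", "known", "first", "only" and "open" are said of these compounds alone.

Compound 1, `CC(C)[C@@H]1CC[C@H](CO)[C@]12CC[C@@](C)(O)[C@H]1O[C@H]12`: "not determined" (no result reported)
Compound 2, `CC(C)C1=CC[C@H](CS(=O)(=O)c2nc3ccccc3o2)[C@@]12C=CC(=O)CC2`: > 1000000 nM

Two compounds have so far been examined in an assay on HEK293 cells for inhibition of 11-beta-hydroxysteroid dehydrogenase type 2 (Homo sapiens), read by HTRF, with a stated time of 2 h, in the presence of a further agent that is not named here; on this read-out lower numbers stand for stronger inhibition and higher numbers for weaker inhibition. For compound 1, with the structure `CC(C)[C@@H]1CC[C@H](CO)[C@]12CC[C@@](C)(O)[C@H]1O[C@H]12`, the outcome in this assay is recorded as "not determined" (no result reported), so no number exists for it. Compound 2, with the structure `CC(C)C1=CC[C@H](CS(=O)(=O)c2nc3ccccc3o2)[C@@]12C=CC(=O)CC2`, gives in this assay a value of > 1000000 nM. That value is a limit of the assay rather than a measured number: compound 2 sits at the limit of > 1000000 nM in this assay, at which 1 of the 2 values shown sits, showing no detectable inhibition within the tested range.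

Compound 3, with the structure `CC(C)C1=CC[C@H](CS(=O)(=O)c2nc3ccccc3s2)[C@@]12C=CC(=O)CC2`, differs from compound 2 in one place: 1,3-benzothiazol-2-yl in place of 1,3-benzoxazol-2-yl on a sulfonyl sulfur. Among the measured compounds shown here, no step between two measured compounds is available to guide the comparison. With compound 2 already at the limit in this assay, the change is not expected to produce a step beyond the usual scatter, and the expected step is a number no higher from compound 2 to compound 3 (the limit leaves the size open). Compound 3 is therefore expected to give roughly 1000000 nM in this assay, with an expected range from 100000 nM to 10000000 nM, and most likely again only a limit.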

Compound 3, half-maximal inhibitory concentration: > 1000000 nM
Compound 3 was reported as a limit (the forecaster's own chance of this, stated with the estimate: 85%); the middle value sits exactly at the limit.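

In this assay compound 2 and compound 3 are both reported only as limits, and the step from one to the other cannot be read. The compounds shown leave open whether 1,3-benzothiazol-2-yl and 1,3-benzoxazol-2-yl differ at all on this read-out, and whether any compound on this shared core gives an actual number rather than a limit.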